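Diallylamino replacing (ethylcarbamoyl)amino on the shared core

A few compounds are considered here, and "the series" means these few. Any claim that something is new, unique, unknown or untested is made for them only; others in the source may bear on it.

Within the data shown here, in a functional assay on HCT-116 cells (Homo sapiens) for antiproliferative activity, read by MTT assay, with a stated time of 48 h (a lower number here means a stronger inhibitor, a higher number a weaker inhibitor), compound 1 `CCNC(=O)Nc1nc(-c2ccc(OCC)cc2)c(-c2cc(OC)c(OC)c(OC)c2)s1` gives 22.1 nM, the only exact number so far. Compound 2 `CCOc1ccc(-c2nc(N(Cc3ccccc3)Cc3ccccc3)sc2-c2cc(OC)c(OC)c(OC)c2)cc1` is recorded only as a limit of the assay, > 5000 nM. Compound 3 `C=CCN(CC=C)c1nc(-c2ccc(OCC)cc2)c(-c2cc(OC)c(OC)c(OC)c2)s1` has not yet been measured. It carries diallylamino in place of (ethylcarbamoyl)amino on an aromatic carbon of the core of compound 1, (diallylamino in place of (ethylcarbamoyl)amino on an aromatic carbon). Among the measured compounds shown here, no measured pair isolates this change, so the forecast rests on just two readings and stays loose. For the measured compounds named here, the expectation of weaker inhibition leans on compound 2, with its limit of > 5000 nM as the only other reading. The expected step in this assay is a 68-fold higher number from compound 1 to compound 3 (1.83 log units; beyond the scatter), a loss beyond the scatter. For compound 3 the estimated value is 1500 nM, with an expected range of 150 nM to 10000 nM.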

Compound 3, half-maximal inhibitory concentration: > 5000 nM
Compound 3: no number, only a limit; the forecaster's own chance of this, stated with the estimate: 35%; middle value at least 3.3-fold (0.52 log units) away from the limit.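

Among these compounds, replacing (ethylcarbamoyl)amino with diallylamino on the shared core gives an at least 220-fold higher number from compound 1 to compound 3 (2.35 log units; beyond the scatter), the first measured pair at this position and direct evidence in this assay that this change is not tolerated. Compound 3 is recorded only as a limit of the assay, > 5000 nM, so the full size of the loss cannot be read. Values at this limit now recur in the series, leaving compound 1 as the only exact reading: the limit of > 5000 nM in this assay, at which 2 of the 3 values shown sit.

The change removes the hydrogen-bond donors and the carbonyl and also alters the size of the group, so these compounds do not separate those differences. An unsubstituted amino group or an acetamido group at this position would show whether activity survives with only part of the urea retained.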